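Swapping a Benzyl Group for a Methoxyphenyl Group

The compounds below may be only part of what the source reports. "The series", "measured", "known", "first", "only" and "open" are said of these compounds alone.

Compound 1 `CCOC(=O)CN(Cc1ccccc1)c1nc(NCc2ccccc2)ncc1[N+](=O)[O-]` was tested in a functional assay on MDA-MB-231 cells (Homo sapiens) for antiproliferative activity, read by MTT assay, with a stated time of 48 h (on this read-out higher numbers stand for weaker inhibition and lower numbers for stronger inhibition), where compound 1 gives 82400 nM, the highest of the two numbers reported there. Compound 2 `COC(=O)CN(C)c1nc(Nc2ccc(Cl)cc2)ncc1[N+](=O)[O-]` gives 21200 nM in this assay. Compound 3 `COC(=O)CN(C)c1nc(Nc2ccccc2)ncc1[N+](=O)[O-]` gives a limit, > 100000 nM, in this assay. Among the measured compounds shown here, the one step measured in a single place, an at least 4.7-fold higher number from compound 2 to compound 3 (0.67 log units; beyond the scatter), concerns a chloro group and is capped by the limit of > 100000 nM in this assay, at which 1 of the 3 values shown sits. For the measured compounds named here, compound 4 `CCOC(=O)CN(Cc1ccccc1)c1nc(Nc2cccc(OC)c2)ncc1[N+](=O)[O-]` differs from compound 1 by 3-methoxyphenyl in place of benzyl on a nitrogen on an aromatic ring, a change no measured step covers, although compound 2 and compound 3 show that a ring placed directly on that nitrogen can give either a lower or a higher number than compound 1. Compound 4 is therefore expected at 50000 nM, between 15000 nM and 150000 nM, an expected step of a 1.6-fold lower number from compound 1 to compound 4 (0.22 log units; within the scatter).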

Compound 4, half-maximal inhibitory concentration: 47200 nM
Beside the measured number, compound 4's estimate is 1.1-fold (0.03 log units) above it, and the stated range covers the measured number.
By their numbers in this assay, from the lowest: compound 2; then compounds 4 and 1 (each within the scatter of the next). At a limit, above all of these: compound 3.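

Among the compounds shown here, the step of a 1.7-fold lower number from compound 1 to compound 4 (0.24 log units; within the scatter) in this assay is the first direct comparison at this position, where the rest of the molecule stays the same. It shows that benzyl can give way to 3-methoxyphenyl, which puts the aromatic ring directly on the nitrogen, without a difference that can be told from the usual scatter.

As far as these compounds go, how a carboxylic acid or an amine in place of the methoxy group would read on this core remains open. Nothing shown here offers an explanation for the size of this step.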